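Solubility notes: fluoro for trifluoromethyl on the aromatic ring

This account rests on a few compounds, and the source may have more. Where it says the series, first, only, none or still open, it means among the compounds named here.

In a physicochemical assay for solubility, using the shake flask method, in simulated intestinal fluid, measured as kinetic solubility, with a stated time of 20 h, at pH 6.5 (on this read-out lower numbers stand for lower solubility and higher numbers for higher solubility), compound 1 `Fc1ccc(Nc2cc3[nH]c(-c4ccc(F)c(F)c4)nc3cn2)nc1` gives >= 50000 nM, which is a limit of the assay and not a number. Among the measured compounds shown here, compound 2 `FC1(F)CCC(c2nc3cnc(Nc4ccc(C(F)(F)F)cn4)cc3[nH]2)CC1` gives 93000 nM, the only actual number so far. Compound 3 `Fc1ccc(Nc2cc3[nH]c(C4CCC(F)(F)CC4)nc3cn2)nc1` carries fluoro in place of trifluoromethyl on an aromatic carbon of a six-membered aromatic ring with 1 nitrogen, two atoms from the ring nitrogen and para to a large group (fluoro in place of trifluoromethyl on an aromatic carbon). For the measured compounds named here, no measured pair yet differs in one place, so nothing shows how far such a change moves this assay. The expectation is therefore no shift in either direction beyond the usual scatter, anchored on compound 2 at 93000 nM. The expected move is a 1.0-fold lower number from compound 2 to compound 3 (0.01 log units; within the scatter). For compound 3 the estimated value is 90000 nM, with an expected range of 45000 nM to 180000 nM.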

Compound 3, solubility: 170000 nM
Compound 3: the middle estimate sits 1.9-fold (0.28 log units) below what was measured; measured number inside the range.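

In this assay, fluoro in place of trifluoromethyl on an aromatic carbon, two atoms from the ring nitrogen and para to a large group, gives a 1.8-fold higher number from compound 2 to compound 3 (0.26 log units; within the scatter). Among the compounds shown here, this is the first readable one-place step, and on this single pair the change does not move the read-out beyond the usual scatter. The step from compound 1 to compound 3, where 4,4-difluorocyclohexyl replaces 3,4-difluorophenyl, cannot be read because one end of it is a limit and not a number: the limit of >= 50000 nM in this assay, at which 1 of the 3 values shown sits.

One pair cannot show whether the same swap behaves alike with 3,4-difluorophenyl in place of 4,4-difluorocyclohexyl. From the compounds shown here alone, how a nitrile or a methoxy group at this place would read in this assay also stays open.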